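The compounds below may be only part of what the source reports. "The series", "measured", "known", "first", "only" and "open" are said of these compounds alone.

Of the compounds shown here, two of a shared core have been measured in an assay on membranes from HeLa cells for displacement of a labelled ligand from adenosine receptor A3 (Homo sapiens), read by scintillation counting, with a stated time of 180 min, tested at 1 uM; a higher number here means more inhibition at the concentration tested (going by the name of the read-out), a lower number less inhibition. Compound 1 `CC1=C(C(=O)SC(C)C)C(c2cccs2)NC(=O)N1` gives 1% there, and compound 2 `CC1=C(C(=O)OC2CCC2)C(c2ccco2)NC(=O)N1` gives 1%. Compound 2 thus stands level with compound 1 at the digits reported, the two values lying within the scatter of each other, so no order between them can be read. Compound 3 `CC1=C(C(=O)OC2CCC2)C(c2cccs2)NC(=O)N1` is the next member. The change from compound 2 to compound 3 is thiophen-2-yl in place of furan-2-yl on a saturated ring carbon. Within the data shown here, no step between measured compounds is available, so nothing is known about how such an exchange moves the read-out; what is known is that compound 1, which also carries thiophen-2-yl, gives 1% in this assay. On that basis compound 3 is expected to stay near compound 2. The estimated step is a number 1 percentage points higher from compound 2 to compound 3 (within the scatter), none beyond the scatter. Compound 3 is therefore estimated at 2%, within a range from 0% to 12%.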

Compound 3, a percentage reported as inhibition, at one concentration (the size of the read-out at that concentration, not a potency): 2%
Beside the measured number, compound 3's estimate shows no gap at the digits printed; the range from low to high includes it.
By their numbers in this assay, from the lowest: compounds 1, 2 and 3 (each within the scatter of the next).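

In this assay, among these compounds, thiophen-2-yl in place of furan-2-yl on the saturated ring carbon gives a number 1 percentage points higher from compound 2 to compound 3 (within the scatter), the first direct reading of this exchange, and it does not tell the two rings apart at this position. With thiophen-2-yl held in place, cyclobutyloxy in place of isopropylsulfanyl on the carbonyl carbon gives a number 1 percentage points higher from compound 1 to compound 3 (within the scatter), so this exchange does not separate its two groups either. No measurement at hand offers an explanation for these readings.

As far as these compounds go, all three compounds carry a five-membered aromatic ring with 1 hetero atom on the saturated ring carbon, so it remains open whether a phenyl ring or an aminomethyl group there would give a different reading. Also open, from the compounds shown here alone, is whether a carboxylic acid or a longer alkoxy chain at the carbonyl carbon would do so.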